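This account rests on a few compounds, and the source may have more. Where it says the series, first, only, none or still open, it means among the compounds named here.

Values from a functional assay on NALM-6 cells (Homo sapiens) for cytotoxicity, read by luminescence and CellTiter-Glo, with a stated time of 3 days (on this read-out lower numbers stand for stronger inhibition and higher numbers for weaker inhibition), follow.

Compound 1 `Cc1cc(C#N)ccc1NC(=O)c1ccc2cccnc2c1O` gives 230 nM
Compound 2 `N#Cc1ccc(NC(=O)c2ccc3cccnc3c2O)cc1` gives 130 nM

Within the data shown here, with only two numbers, compound 2 has a single neighbour, and the gap to it stays within the scatter. That gap is a 1.8-fold lower number from compound 1 to compound 2 (0.25 log units; within the scatter) and comes from swapping hydrogen in place of methyl on an aromatic carbon.

The next compound, compound 3 `O=C(Nc1ccc(C(F)(F)F)cc1)c1ccc2cccnc2c1O`, carries trifluoromethyl in place of cyano on an aromatic carbon, para to a large group (trifluoromethyl in place of cyano on an aromatic carbon). Among the measured compounds shown here, no measured step makes this exchange, so the one step available is only a weak guide. It does show one small change leaving this assay within the scatter, so no large shift is expected here, perhaps a slight move towards a higher number. The expected change is a 1.4-fold higher number from compound 2 to compound 3 (0.14 log units; within the scatter) and would not clearly exceed the scatter. For compound 3 the estimated value is 180 nM, with an expected range from 60 nM to 540 nM.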

Compound 3, half-maximal inhibitory concentration: 380 nM
For compound 3 the middle estimate is 2.1-fold (0.32 log units) below the measured one, within the range that was stated.
By their numbers in this assay, from the lowest: compounds 2, 1 and 3 (each within the scatter of the next, the first and the last beyond it).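

Among these compounds, at this place on the ring, para to a large group, trifluoromethyl in place of cyano gives the first single change to go beyond the scatter in this assay (a 2.9-fold higher number from compound 2 to compound 3 (0.47 log units; beyond the scatter)). Among the compounds shown here, the earlier step, hydrogen in place of methyl on an aromatic carbon, stayed within the scatter, so this is the first sign that the read-out responds to a change on this ring, although the shift is modest. Nothing available explains why the number moves in this direction.

Going by these compounds, only cyano and trifluoromethyl appear at this place, so it remains open how an amine, a carboxylic acid or a longer chain would read there. Also open, on these data alone, is whether the methyl step would stay within the scatter with trifluoromethyl in place of cyano.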